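Replacing the aryl on the pyridazinone nitrogen of compound 2

A few compounds are considered here, and "the series" means these few. Any claim that something is new, unique, unknown or untested is made for them only; others in the source may bear on it.

Among the compounds with values here, compound 2 `Cc1cc(=O)n(-c2ccccc2C(F)(F)F)nc1C(=O)Nc1ccc(Oc2ncnc3ccsc23)c(F)c1` is one of two compounds measured in a functional assay on A549 cells (Homo sapiens) for cytotoxicity, read by MTT assay, with a stated time of 72 h; a lower number here means a stronger inhibitor, a higher number a weaker inhibitor. In this assay, within the data shown here, compound 2 gives 4680 nM; compound 1 `Cc1cc(=O)n(-c2ccccc2C(F)(F)F)nc1C(=O)Nc1ccc(Oc2ncnc3ccsc23)cc1` gives 8850 nM, and the only measured step is a 1.9-fold lower number from compound 1 to compound 2 (0.28 log units; within the scatter), so the two numbers cannot be told apart. Compound 3 `Cc1ccc(-n2nc(C(=O)Nc3ccc(Oc4ncnc5ccsc45)c(F)c3)c(C)cc2=O)cc1` differs from compound 2 in a single place: 4-methylphenyl in place of 2-(trifluoromethyl)phenyl on an aromatic nitrogen. Among the measured compounds shown here, the measured step from compound 1 to compound 2 concerns a different position of the shared core and does not bear on this change; no measured step touches the group on the aromatic nitrogen. With nothing to anchor a direction, the expected step of a 1.1-fold higher number from compound 2 to compound 3 (0.03 log units; within the scatter) is none beyond the scatter, though the range must be wide. Compound 3 is therefore estimated at 5000 nM in this assay, between 1200 nM and 20000 nM.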

Compound 3, half-maximal inhibitory concentration: 5890 nM
The estimate for compound 3 lay 1.2-fold (0.07 log units) below the measured number, and the stated range covers the measured number.
By their numbers in this assay, from the lowest: compounds 2, 3 and 1 (each within the scatter of the next).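

In this assay, within the data shown here, the change on the aromatic nitrogen gives a 1.3-fold higher number from compound 2 to compound 3 (0.10 log units; within the scatter), the first measured step at this position. On the core of compound 2, 2-(trifluoromethyl)phenyl and 4-methylphenyl therefore cannot be told apart, even though they differ in both their substituent and its place on the phenyl ring. Nothing available explains why the two groups read alike.

The two aryl groups shown leave open whether any group on this nitrogen can move the number beyond the scatter. A phenyl ring carrying a carboxylic acid or an amine, or a simple alkyl chain in place of the aryl, might behave differently, and the effect of the substituent's place on the ring cannot be separated from that of its identity.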